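Change of the Substituent on the Ring Nitrogen of the Shared Core

The compounds below may be only part of what the source reports. "The series", "measured", "known", "first", "only" and "open" are said of these compounds alone.

Of the compounds shown here, two have been measured in an assay on membranes from striatum for displacement of a labelled ligand from sodium-dependent dopamine transporter (Rattus norvegicus); on this read-out higher numbers stand for weaker inhibition and lower numbers for stronger inhibition. Compound 1 `CN1CCC(OC(c2ccc(Cl)cc2)c2ccc(Cl)cc2)CC1` gives 44 nM, and compound 2 `CCCCN1CCC(OC(c2ccc(Cl)cc2)c2ccc(Cl)cc2)CC1` gives 12.5 nM. Within the data shown here, the only step between them, a 3.5-fold lower number from compound 1 to compound 2 (0.55 log units; beyond the scatter), shows that lengthening the chain on the ring nitrogen is tolerated well. On the numbers shown, compound 2 stands lowest of the two, with compound 1 the nearest and clearly apart from it.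

Compound 3 `Fc1ccc(CN2CCC(OC(c3ccc(Cl)cc3)c3ccc(Cl)cc3)CC2)cc1` carries the change (4-fluorophenyl in place of propyl on a saturated chain carbon bound to an amine nitrogen in a ring). Among the measured compounds shown here, the only measured step that bears on this position, a 3.5-fold lower number from compound 1 to compound 2 (0.55 log units; beyond the scatter), was modest and went toward lower numbers, but it covered a chain of three carbons and says nothing directly about an aromatic ring at the same place. The author therefore expects the step of a 1.0-fold lower number from compound 2 to compound 3 (0.02 log units; within the scatter) to lie within the scatter, with no clear direction. For compound 3 the estimate in this assay is 12 nM, with a range from 4 nM to 40 nM.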

Compound 3, half-maximal inhibitory concentration: 50.6 nM
Compound 3: the middle estimate sits 4.2-fold (0.62 log units) below what was measured, and the stated range ends below it.
By their numbers in this assay, from the lowest: compound 2; then compounds 1 and 3 (each within the scatter of the next).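

In this assay, among these compounds, the step of a 4.0-fold higher number from compound 2 to compound 3 (0.61 log units; beyond the scatter) shows that this position does not simply reward a bigger group: the butyl chain of compound 2 gave the lowest number so far, and 4-fluorobenzyl, with its aromatic ring, does not keep it. The step of a 1.2-fold higher number from compound 1 to compound 3 (0.06 log units; within the scatter) lies within the scatter, so compound 3 stands level with compound 1, and on these three compounds the kind of group at this place matters, with compound 2 alone clearly apart from the other two. Nothing shown here gives a measured reason for the difference between the butyl chain and the 4-fluorobenzyl group.

The compounds shown leave open whether the aromatic ring itself or the fluorine on it goes with the higher number, a question that unsubstituted benzyl would address. They also leave open whether a longer chain such as hexyl, or 2-phenylethyl with its ring set further out, would stay near compound 2 or fall level with compound 3.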